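From Carboxy to Carbamoyl on a Shared Core

The source may report more compounds than this note shows. Statements on the series, on what has been measured and on what is new or still open speak of the compounds shown alone.

Compound 1 `CN1CCN(c2ccc(Nc3nc(-c4cccc(NC(=O)c5ccccc5)c4)sc3C(=O)O)cc2)CC1`: no result in a functional assay on Raji cells (Homo sapiens) for antiproliferative activity, read by CCK-8 assay, with a stated time of 72 h; on this read-out lower numbers stand for stronger inhibition and higher numbers for weaker inhibition
Compound 2 `CN1CCN(c2ccc(Nc3nc(-c4cccc(NC(=O)c5ccccc5F)c4)sc3C(=O)O)cc2)CC1`: 13900 nM
Compound 3 `CN1CCN(c2ccc(Nc3nc(-c4cccc(NC(=O)c5ccc(Cl)cc5)c4)sc3C(=O)O)cc2)CC1`: 7020 nM

Among the two numbers available, compound 3 gives 7020 nM, the lower one, while the step of a 2.0-fold lower number from compound 2 to compound 3 (0.30 log units; within the scatter) lies within the scatter, so neither compound can be called stronger. Compound 1 gives "not determined" (no result reported). Compound 4 `CN1CCN(c2ccc(Nc3nc(-c4cccc(NC(=O)c5ccc(Cl)cc5)c4)sc3C(N)=O)cc2)CC1` is not yet measured; it differs from compound 3 by amino in place of hydroxy on a carbonyl carbon, that is, carboxy to carbamoyl. Among the compounds with values here, no measured step touches this position: the only step available concerns the group on the other carbonyl carbon and was itself within the scatter. The direction of the change is therefore uncertain, and compound 4 is expected to show a step of about a 1.8-fold lower number from compound 3 to compound 4 (0.24 log units; within the scatter), with a wide range. Compound 4 is estimated at 4000 nM, between 800 nM and 20000 nM.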

Compound 4, half-maximal inhibitory concentration: 5700 nM
Compound 4: the middle estimate sits 1.4-fold (0.15 log units) below what was measured; the measured number falls inside the stated range.
By their numbers in this assay, from the lowest: compounds 4, 3 and 2 (each within the scatter of the next, the first and the last beyond it).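

Within the data shown here, this is the first measured step at this position: amino in place of hydroxy on a carbonyl carbon gives a 1.2-fold lower number from compound 3 to compound 4 (0.09 log units; within the scatter). In this assay, carboxy and carbamoyl therefore cannot be told apart on this pair of compounds, which share the 4-chlorophenyl group. No measurement at hand offers a reason for this result.

Going by these compounds, it remains open how a methyl ester or a nitrile would read at this position. Also open, on these data alone, is whether carbamoyl would read the same alongside the 2-fluorophenyl group of compound 2.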